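This account rests on a few compounds, and the source may have more. Where it says the series, first, only, none or still open, it means among the compounds named here.

Working notes on the series, all compounds sharing one core and differing in the substituent on the benzyl ring. In a functional assay on HCT-15 cells (Homo sapiens) for inhibition, read by sulforhodamine B assay (a lower number here means a stronger inhibitor of growth, a higher number a weaker inhibitor of growth), compound 1 `COc1ccccc1CN1CCC=C(CCC(=O)NO)C1=O` reads > 10000 nM, which is a limit of the assay and not a number. Compound 2 `COc1cccc(CN2CCC=C(CCC(=O)NO)C2=O)c1` gives a measured 9030 nM. Compound 3 `CC(=O)Nc1ccc(CN2CCC=C(CCC(=O)NO)C2=O)cc1` has no number at all: its entry in this assay reads "not determined" (no result reported), so it stands nowhere on the scale and offers no starting point.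

The next compound to be tested is compound 4 `COc1ccc(CN2CCC=C(CCC(=O)NO)C2=O)cc1`. The change methoxy in place of acetamido on an aromatic carbon puts methoxy in place of acetamido on an aromatic carbon, para to a large group.

Among the compounds with values here, no step between measured compounds is available, and the step in question has no measured start. Its size in this assay therefore cannot be read from the data, and no direction can be assigned to it. Within the data shown here, the working expectation is that compound 4 falls in the same region as the one true number, with compound 2 at 9030 nM, and differs from it by no more than the scatter. A reading at the limit of the assay would also not be a surprise. Compound 4 is expected at an estimated 8000 nM, with an estimated range from 3000 nM to 20000 nM.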

Compound 4, concentration for 50% growth inhibition: 6890 nM
Estimate against measurement, compound 4: 1.2-fold (0.06 log units) above; measured number inside the range.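

Within the data shown here, compound 4 yields no new step: compound 3 has no number in this assay, so the change from acetamido to methoxy between compound 3 and compound 4 cannot be read. What acetamido in that place does to growth inhibition in this assay stays open, and the values shown include one limit: the limit of > 10000 nM in this assay, at which 1 of the 4 values shown sits.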